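Three measured analogues and a trifluoromethyl newcomer

This account rests on a few compounds, and the source may have more. Where it says the series, first, only, none or still open, it means among the compounds named here.

Compound 1 `O=Cc1ccc(-c2cn3ccnc3c(-c3ccc4ncn(C5CCCCC5)c4c3)n2)cc1`: in a functional assay on HCT-116 cells (Homo sapiens) for inhibition, read by sulforhodamine B assay, with a stated time of 48 h, tested at 10 uM (a higher number here means more inhibition at the concentration tested (going by the name of the read-out), a lower number less inhibition), compound 1 gives 92.6%.
Compound 2 `c1ccc2c(-c3cn4ccnc4c(-c4ccc5ncn(C6CCCCC6)c5c4)n3)cccc2c1`: compound 2 gives 17.9%.
Compound 3 `COc1ccccc1-c1cn2ccnc2c(-c2ccc3ncn(C4CCCCC4)c3c2)n1`: compound 3 gives 28.3%.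

Compound 3 stands second highest of the three numbers: a number 10.4 percentage points higher from compound 2 to compound 3 (beyond the scatter), and a number 64.3 percentage points lower from compound 1 to compound 3 (beyond the scatter). Compound 4 `FC(F)(F)c1cccc(-c2cn3ccnc3c(-c3ccc4ncn(C5CCCCC5)c4c3)n2)c1` differs from compound 3 in one place: 3-(trifluoromethyl)phenyl in place of 2-methoxyphenyl on an aromatic carbon. For the measured compounds named here, no measured step swaps the 2-methoxyphenyl for the 3-(trifluoromethyl)phenyl, so the guidance is indirect. The two departures from the 4-formylphenyl of compound 1, a number 74.7 percentage points lower from compound 1 to compound 2 (beyond the scatter) and a number 64.3 percentage points lower from compound 1 to compound 3 (beyond the scatter), were both large drops, while the move between the two lower compounds, a number 10.4 percentage points higher from compound 2 to compound 3 (beyond the scatter), was modest. The 3-(trifluoromethyl)phenyl of compound 4 is a third substituted phenyl to be tested in this position, and the two such groups already measured, in compound 2 and compound 3, both fall well below compound 1. Compound 4 is therefore expected to stay in the lower region, with a step of a number 6.3 percentage points lower from compound 3 to compound 4 (within the scatter) that is expected to lie within the scatter, leaning downward if anywhere. Compound 4 is estimated at 22%, with a range from 5% to 50%.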

Compound 4, a percentage reported as inhibition, at one concentration (the size of the read-out at that concentration, not a potency): 17.6%
Compound 4: the middle estimate sits 4.4 percentage points above what was measured; the measured number falls inside the stated range.
By their numbers in this assay, from the lowest: compounds 4 and 2 (each within the scatter of the next); then compound 3; then compound 1.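

The 3-(trifluoromethyl)phenyl is a third group at this aromatic carbon to fall far short of the 4-formylphenyl, with a number 75 percentage points lower from compound 1 to compound 4 (beyond the scatter), so among the four compounds only compound 1 keeps a high number in this assay. Below compound 1 the groups separate only slightly: the 2-methoxyphenyl holds a modest edge, with a number 10.7 percentage points lower from compound 3 to compound 4 (beyond the scatter), while the naphthalen-1-yl and the 3-(trifluoromethyl)phenyl cannot be told apart, with a number 0.3 percentage points lower from compound 2 to compound 4 (within the scatter). Nothing available explains why the 4-formylphenyl stands so far apart from the other three groups.

The compounds shown leave open whether the high number of compound 1 belongs to the formyl group itself or would survive with another group in its place on the phenyl, which a 4-carboxyphenyl or a 4-(aminomethyl)phenyl would help to settle. They also leave open whether the small differences among compound 2, compound 3 and compound 4 in this assay would persist across a range of concentrations, since each number comes from a single concentration.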